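Compound 1 and its methyl analogue, compound 3

The source may report more compounds than this note shows. Statements on the series, on what has been measured and on what is new or still open speak of the compounds shown alone.

Compound 1 `COc1ccc(/C=C2\S/C(=N\c3ccc(Cl)cc3)N(C)C2=O)cc1` gives 10400 nM as measured
Compound 2 `COc1ccc(/C=C2/CN(C)/C(=N/c3ccc([N+](=O)[O-])cc3)S2)cc1` gives 10200 nM as measured

In a functional assay on HCT-116 cells (Homo sapiens) for antiproliferative activity, read by MTT assay, with a stated time of 72 h (a higher number here means a weaker inhibitor, a lower number a stronger inhibitor), compound 1 gives 10400 nM and compound 2 gives 10200 nM in the same test. For the measured compounds named here, these two numbers lie within the usual scatter of each other, so compound 1 stands level with the only other measured compound. Neither can be ranked above the other.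

Compound 3 `COc1ccc(/C=C2\S/C(=N\c3ccc(C)cc3)N(C)C2=O)cc1` has not yet been measured. It differs from compound 1 at a single place, with methyl in place of chloro on an aromatic carbon, para to a large group (methyl in place of chloro on an aromatic carbon). The same difference can be read as 4-chlorophenyl to 4-methylphenyl.

Going by the values given here, the measured compounds include no pair that differs in one place, so the data give no direct guide to this change. No shift beyond the scatter is therefore expected in this assay and no direction is favoured, leaving the expected step (a 1.1-fold higher number from compound 1 to compound 3 (0.02 log units; within the scatter)) small.

For compound 3 the estimated value is 11000 nM in this test, with an expected range from 4500 nM to 27000 nM as its limits.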

Compound 3, half-maximal inhibitory concentration: > 100000 nM
Compound 3: a limit, no number; the forecaster's own chance of this, stated with the estimate: 8%; middle value at least 9.0-fold (0.95 log units) from the limit.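

For compound 3 the reading is a limit of the assay and not a number: the limit of > 100000 nM in this assay, at which 1 of the 3 values shown sits. In this assay, for the compounds shown here, the change from 4-chlorophenyl to 4-methylphenyl gives an at least 9.6-fold higher number from compound 1 to compound 3 (0.98 log units; beyond the scatter), the first single-place comparison in this set, and it shows that the group on this aromatic carbon, para to a large group, matters to the read-out. Chloro and methyl have the same heavy-atom count and match in hydrogen-bond donors, hydrogen-bond acceptors and net charge, so these counts do not separate the two groups, yet the step lies beyond the scatter.

The compounds shown leave open whether a fluoro, a trifluoromethyl or an amine at this place would read like compound 1 or like compound 3, and how far the step really reaches, since its upper end is not fixed. They also leave open whether the same exchange would have a comparable effect on the core of compound 2, which differs from compound 1 in more than one place and so offers no direct comparison.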